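Swapping the Aryl Group on the Shared Core

The compounds below may be only part of what the source reports. "The series", "measured", "known", "first", "only" and "open" are said of these compounds alone.

Of the compounds shown here, two have so far been measured in a functional assay on HCC827 cells (Homo sapiens) for inhibition, read by MTT assay, with a stated time of 48 h, tested at 10 uM; on this read-out lower numbers stand for less inhibition and higher numbers for more inhibition at the one concentration tested (going by the name of the read-out). Compound 1 `COc1cc(Br)ccc1Nc1cc(NC(=O)Nc2c(Cl)cccc2Cl)ncn1` gives 42.7%. Compound 2 `COc1ccc(Br)cc1Nc1cc(NC(=O)Nc2c(Cl)cccc2Cl)ncn1` gives 53%, the highest of the two numbers; it differs from compound 1 only in carrying a 5-bromo-2-methoxyphenyl in place of a 4-bromo-2-methoxyphenyl on a nitrogen on an aromatic ring, and that change gave a number 10.3 percentage points higher from compound 1 to compound 2 (beyond the scatter). Compound 3 `O=C(Nc1cc(Nc2ccc(F)c(Cl)c2)ncn1)Nc1c(Cl)cccc1Cl` has not yet been measured. It differs from compound 2 as follows: 3-chloro-4-fluorophenyl in place of 5-bromo-2-methoxyphenyl on a nitrogen on an aromatic ring. Here the bromine and the methoxy group leave together and a ring carrying chlorine and fluorine enters, so the one measured step, which only exchanged 4-bromo-2-methoxyphenyl for 5-bromo-2-methoxyphenyl, bears on it only loosely. It shows that a small rearrangement of this part of the molecule moved this assay by a modest amount, but it offers no guide to removing the methoxy group altogether. With only that to go on, no step beyond the scatter is expected in either direction, and compound 3 is estimated at 46%, within 26% to 66%. That estimate is expected to mean a number 7 percentage points lower from compound 2 to compound 3 (within the scatter).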

Compound 3, a percentage reported as inhibition, at one concentration (the size of the read-out at that concentration, not a potency): 53.7%
Compound 3: middle estimate off by 7.7 percentage points, on the low side; the range from low to high includes it.
By their numbers in this assay, from the lowest: compound 1; then compounds 2 and 3 (each within the scatter of the next).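

In this assay, the bromine and the methoxy group can leave together with no change beyond the scatter: 3-chloro-4-fluorophenyl in place of 5-bromo-2-methoxyphenyl on this nitrogen gives a number 0.7 percentage points higher from compound 2 to compound 3 (within the scatter) and so cannot be told apart from it here. The same ring in place of 4-bromo-2-methoxyphenyl gives a number 11 percentage points higher from compound 1 to compound 3 (beyond the scatter) and so leaves compound 1 as the lowest of the three, the only one that stands apart in this small set. Nothing given here explains why these rings compare as they do.

Every ring shown at this position is a six-membered aromatic ring of carbon carrying at least one halogen, so it remains open how a plain phenyl ring, or a phenyl ring bearing an amine or a carboxylic acid, would read at the same place. Also open, going by these compounds, is whether the chlorine or the fluorine alone on the ring would give a similar number, since 3-chloro-4-fluorophenyl carries both at once.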